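The source may report more compounds than this note shows. Statements on the series, on what has been measured and on what is new or still open speak of the compounds shown alone.

Working notes on the series. Compound 1 `O=C(CCSc1nnc(-c2ccncc2)s1)Nc1ccccc1` carries a phenyl on an amide-type nitrogen. In an ADME assay on HepG2 cells (Homo sapiens) for cytotoxicity, with a stated time of 3 days (on this read-out higher numbers stand for lower toxicity in this test and lower numbers for higher toxicity in this test), compound 1 gives only a limit of the assay, > 50000 nM. Compound 2 `O=C(CCSc1nnc(-c2ccncc2)s1)NCc1ccccc1Cl` has a 2-chlorobenzyl in place of that phenyl on the amide-type nitrogen. In this assay compound 2 likewise gives only a limit of the assay, > 50000 nM. The step that the two limits leave unreadable from compound 1 to compound 2 is therefore one from which no size can be read, since both ends sit at the limit of > 50000 nM in this assay, at which 2 of the 2 values shown sit. For the measured compounds named here, compound 2 thus stands only as a limit, and the one further value shown is a limit as well. Compound 3 `CC(CSc1nnc(-c2ccncc2)s1)C(=O)NCc1ccccc1Cl` differs from compound 2 by methyl in place of hydrogen on a saturated chain carbon bound to a carbonyl carbon and a saturated chain carbon. Going by the values given here, the only measured step bears on this change solely in that both of its ends sit at the limit, so it offers no readable size in either direction. The expectation in this assay is that compound 3 also remains at the limit. For compound 3 the estimate in this assay is 80000 nM, with an expected range of 40000 nM to 200000 nM. The expected step is a step that the limit leaves unreadable from compound 2 to compound 3.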

Compound 3, half-maximal cytotoxic concentration: > 50000 nM
Compound 3 was reported as a limit; the forecaster's own chance of this, stated with the estimate: 85%; the middle value lies beyond the limit too.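

Compound 3, like compound 2, gives only a limit, so no step can be read from compound 2 to compound 3, and all values shown sit at one limit: the limit of > 50000 nM in this assay, at which 3 of the 3 values shown sit. The compounds shown leave open the size and direction of the effect of methyl in place of hydrogen, or of any other change in the series, in this assay.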